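This account rests on a few compounds, and the source may have more. Where it says the series, first, only, none or still open, it means among the compounds named here.

Compound 1 `Fc1ccccc1Cn1nnc2c(NC3CCCCC3)nc(-c3ccccc3)nc21` gives 1150000 nM in an assay on isolated protein for binding affinity to adenosine receptor A1 (Bos taurus); on this read-out higher numbers stand for weaker inhibition and lower numbers for stronger inhibition.
Compound 2 `OCCNc1nc(-c2ccccc2)nc2c1nnn2Cc1ccccc1F` gives 54000000 nM in this assay.
Compound 3 `COc1ccc(C(=O)Nc2nc(-c3ccccc3)nc3c2nnn3Cc2ccccc2Cl)cc1` gives 20000000 nM in this assay.

Among these three, compound 3 stands second highest: compound 2 lies above it and compound 1 well below it. Going by the values given here, the only single-point step in this set is a 47-fold higher number from compound 1 to compound 2 (1.67 log units; beyond the scatter), which concerns the group on the ring nitrogen, not the halogen of the benzyl group. Compound 4 `COc1ccc(C(=O)Nc2nc(-c3ccccc3)nc3c2nnn3Cc2ccccc2F)cc1` differs from compound 3 by fluoro in place of chloro on an aromatic carbon. Among the compounds with values here, no measured pair in this set bears on such a halogen exchange, so there is no basis for expecting a shift beyond the scatter in this assay in either direction. Compound 4 is therefore expected to give about 20000000 nM, within a range from 6000000 nM to 60000000 nM, and the step of no change at the digits printed from compound 3 to compound 4 (within the scatter) is estimated to stay within the scatter.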

Compound 4, inhibition constant: 21900000 nM
Beside the measured number, compound 4's estimate is 1.1-fold (0.04 log units) below it, within the range that was stated.
By their numbers in this assay, from the lowest: compound 1; then compounds 3 and 4 (each within the scatter of the next); then compound 2.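

In this assay the change from 2-chlorobenzyl to 2-fluorobenzyl gives a 1.1-fold higher number from compound 3 to compound 4 (0.04 log units; within the scatter) and so leaves the number unmoved with (4-methoxyphenyl)carbonyl on the nitrogen. With 2-fluorobenzyl held constant, the nitrogen group still matters: the series shows a 2.5-fold lower number from compound 2 to compound 4 (0.39 log units; beyond the scatter) and a 19-fold higher number from compound 1 to compound 4 (1.28 log units; beyond the scatter) as the group changes, placing (4-methoxyphenyl)carbonyl between 2-hydroxyethyl and cyclohexyl. Nothing available explains these steps. As far as these compounds go, it remains open whether bromo or methyl on that aromatic carbon would behave like fluoro and chloro, and whether the exchange stays silent with cyclohexyl on the nitrogen.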